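The compounds below may be only part of what the source reports. "The series", "measured", "known", "first", "only" and "open" are said of these compounds alone.

In an assay on HEK293 cells for displacement of a labelled ligand from Melanocortin receptor 4 (Homo sapiens) (on this read-out lower numbers stand for stronger inhibition and higher numbers for weaker inhibition), compound 2 `Cc1cc(CC(C)C(=O)N2CCN(c3ccc(C(F)(F)F)cc3[C@@H](N)CC(C)C)CC2)ccc1Cl` gives 71 nM. Among the three numbers so far compound 2 stands second highest: compound 3 `CC(C)C[C@H](N)c1ccccc1N1CCN(C(=O)[C@H](C)Cc2ccc(Cl)cc2F)CC1` gives 67 nM, within the scatter of compound 2, while compound 1 `CC(C)C[C@H](N)c1cc(C(F)(F)F)ccc1N1CCN(C(=O)CNc2ccccc2)CC1` gives 3600 nM, far above both. Compound 4 `CC(C)C[C@H](N)c1cc(C(F)(F)F)ccc1N1CCN(C(=O)COc2ccc(Cl)cc2)CC1` differs from compound 2 in one place: (4-chlorophenoxy)methyl in place of 1-(4-chloro-3-methylbenzyl)ethyl on a carbonyl carbon. Within the data shown here, the one measured step that bears on this exchange is a 51-fold lower number from compound 1 to compound 2 (1.71 log units; beyond the scatter). Among the measured compounds shown here, the entering (4-chlorophenoxy)methyl resembles the anilinomethyl of compound 1 more than the 1-(4-chloro-3-methylbenzyl)ethyl it replaces, so a move back toward a higher number is expected, though the chlorine and the oxygen have no precedent in this set. For compound 4 a step of an 11-fold higher number from compound 2 to compound 4 (1.05 log units; beyond the scatter) is expected, giving an estimate of 800 nM with a range of 200 nM to 3000 nM.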

Compound 4, inhibition constant: 2900 nM
The estimate for compound 4 lay 3.6-fold (0.56 log units) below the measured number, and the stated range covers the measured number.
By their numbers in this assay, from the lowest: compounds 3 and 2 (each within the scatter of the next); then compounds 4 and 1 (each within the scatter of the next).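

Exchanging 1-(4-chloro-3-methylbenzyl)ethyl for (4-chlorophenoxy)methyl on this carbonyl carbon gives a 41-fold higher number from compound 2 to compound 4 (1.61 log units; beyond the scatter) in this assay and returns the number to the level of compound 1. With 4-chlorophenoxy in place of anilino on the saturated chain carbon, the step is a 1.2-fold lower number from compound 1 to compound 4 (0.09 log units; within the scatter) and the two groups stand level, so a chlorine on the aromatic ring does not by itself restore the low number. Nothing at hand explains the large step.

Open, on these data alone, is whether a 4-chlorobenzyl group or a longer carbon chain ending in 4-chlorophenyl on this carbonyl carbon would keep the low number of compound 2.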